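Swapping a Saturated Ring for a Chlorinated Aromatic One

The source may report more compounds than this note shows. Statements on the series, on what has been measured and on what is new or still open speak of the compounds shown alone.

Compound 1 `COc1cc(N)c(Cl)cc1NC(=O)C1CCN(CC2CC2)CC1` gives a limit in a functional assay on the whole organism for antagonist activity, with Mus musculus as the target (a higher number here means that more compound is needed for the effect, a lower number that less compound is needed), not a number: > 10 mg/kg.
Compound 2 `COc1cccc(CN2CCC(C(=O)Nc3cc(Cl)c(N)cc3OC)CC2)c1` likewise gives only a limit: > 4 mg/kg.
Compound 3 `COc1cc(N)c(Cl)cc1NC(=O)C1CCN(CC2CCCCC2)CC1` gives 2.9 mg/kg.

Among the three measured compounds, compound 3 is the only one with a definite number in this assay; the other two stopped at a limit of the measurement. The step from compound 1 to compound 3 is an at least 3.4-fold lower number from compound 1 to compound 3 (0.53 log units; beyond the scatter). The step from compound 2 to compound 3 is an at least 1.3-fold lower number from compound 2 to compound 3 (0.13 log units; that floor lies within the scatter), and the step from compound 1 to compound 2 is a step that the two limits leave unreadable from compound 1 to compound 2.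

Compound 4 `COc1cc(N)c(Cl)cc1NC(=O)C1CCN(Cc2cccc(Cl)c2)CC1` differs from compound 3 in one place: 3-chlorophenyl in place of cyclohexyl on a saturated chain carbon bound to an amine nitrogen in a ring. The closest guide is compound 2, which also carries an aromatic ring on that carbon and reached only a limit. Because the step from compound 2 to compound 3 is an at least 1.3-fold lower number from compound 2 to compound 3 (0.13 log units; that floor lies within the scatter), a return to an aromatic ring is expected to raise the number, though the chlorine on the ring leaves the size uncertain. The step from compound 3 to compound 4 is therefore estimated at a 1.7-fold higher number from compound 3 to compound 4 (0.24 log units; within the scatter). For compound 4 the expected value in this assay is 5 mg/kg, with a likely range from 2 mg/kg to 15 mg/kg.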

Compound 4, dose for half-maximal effect: > 4 mg/kg
Compound 4: a limit, no number; the forecaster's own chance of this, stated with the estimate: 45%; the middle value is on the limit's open side.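

Putting 3-chlorophenyl in place of cyclohexyl on a saturated chain carbon bound to an amine nitrogen in a ring gives an at least 1.3-fold higher number from compound 3 to compound 4 (0.13 log units; that floor lies within the scatter), so this change is not shown to make a real difference in this assay, and its true size stays unknown. Compound 4, with chloro where compound 2 has methoxy on an aromatic carbon, also ends in a limit rather than a number, the same limit as compound 2: the limit of > 4 mg/kg in this assay, at which 2 of the 4 values shown sit. The steps linking compound 4 to compound 1 and to compound 2 cannot be read, as each joins two limits, so neither swapping methoxy for chloro nor swapping cyclopropyl for 3-chlorophenyl can be given a size.

Compound 3 alone has a definite number, but compound 1, which also has a saturated ring at this place, ends in a limit, so the compounds shown do not establish that a saturated ring is enough. Cyclopentyl on that same carbon could help show how the result follows ring size, and an amine on the aromatic ring could test whether any aromatic group there can give a definite number.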